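The source may report more compounds than this note shows. Statements on the series, on what has been measured and on what is new or still open speak of the compounds shown alone.

In a functional assay on HEK293 cells for antagonist activity at P2X purinoceptor 7 (Homo sapiens) (a higher number here means a weaker inhibitor, a lower number a stronger inhibitor), three compounds have been measured so far:
compound 1 `Cc1ccc(-c2ccc(Cl)c(C(=O)NCC3(O)CCCCCC3)c2)nn1` gives 18 nM;
compound 2 `Cc1cnc(-c2ccc(Cl)c(C(=O)NCC3(O)CCCCCC3)c2)cn1` gives 22 nM;
compound 3 `O=C(NCC1(O)CCCC(F)(F)C1)c1cc(-c2ncc(F)cn2)ccc1Cl` gives 51 nM.

Compound 1 has the lowest number of the three. Its nearest neighbour is compound 2, reached by a 1.2-fold higher number from compound 1 to compound 2 (0.09 log units; within the scatter), a step that lies within the scatter, so the two cannot be ordered. Among the measured compounds shown here, compound 3 stands furthest from compound 1, and the gap between their values lies beyond the scatter; but compound 3 differs from compound 1 in more than one place, so no single step joins them.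

Compound 4 `N#Cc1cccc(-c2ccc(Cl)c(C(=O)NCC3(O)CCCCCC3)c2)n1` has not yet been measured. It arises from compound 1 by 6-cyanopyridin-2-yl in place of 6-methylpyridazin-3-yl on an aromatic carbon. For the measured compounds named here, the only measured step that bears on this is the exchange of the aromatic ring at the same place, a 1.2-fold higher number from compound 1 to compound 2 (0.09 log units; within the scatter), which stayed within the scatter. That exchange kept a six-membered ring with two hetero atoms; the change to compound 4 goes further, to a ring with one hetero atom carrying a triple bond outside the ring, so the precedent is only partial. Because a 1.2-fold higher number from compound 1 to compound 2 (0.09 log units; within the scatter) was within the scatter, the step expected in this assay is small, at most a modest move to a higher number. For compound 4 the expected step is a 1.4-fold higher number from compound 1 to compound 4 (0.14 log units; within the scatter). Compound 4 is therefore estimated at 25 nM, with a range from 10 nM to 70 nM.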

Compound 4, half-maximal inhibitory concentration: 232 nM
The estimate for compound 4 lay 9.3-fold (0.97 log units) below the measured number, outside the stated range (above it).
By their numbers in this assay, from the lowest: compounds 1 and 2 (each within the scatter of the next); then compound 3; then compound 4.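

In this assay, the position para to a chloro group turns out to be far from indifferent to the aromatic group it carries: 6-cyanopyridin-2-yl in place of 6-methylpyridazin-3-yl gives a 13-fold higher number from compound 1 to compound 4 (1.11 log units; beyond the scatter), and in place of 5-methylpyrazin-2-yl it gives an 11-fold higher number from compound 2 to compound 4 (1.02 log units; beyond the scatter). Both steps are large, so the earlier tolerance of exchange between the two rings with two hetero atoms does not reach this six-membered aromatic ring with one hetero atom and a nitrile. The leaving and entering groups match in hydrogen-bond acceptors, donors and net charge, so those counts do not separate the compounds, and no measurement is available to explain the large step.

The compounds shown leave open whether the higher number goes with the nitrile or with the ring holding one hetero atom, as both enter in a single change, and a 6-methylpyridin-2-yl group at this place would pull the two apart. Also open, from the compounds shown here alone, is how the same ring would fare carrying a methoxy group or an amine instead of the nitrile.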